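The source may hold more compounds than are shown below. What is called first, only, known or untested is meant among the compounds shown, and "the series" means these compounds.

In a functional assay on SK-OV-3 cells (Homo sapiens) for cytotoxicity, read by MTT assay, with a stated time of 48 h (on this read-out higher numbers stand for weaker inhibition and lower numbers for stronger inhibition), compound 3 `O=C(/C=C/c1ccc2c(c1)B(O)OC2)c1ccc(F)cc1` gives 1400 nM, the lowest of the three numbers measured. Compound 1 `O=C(/C=C/c1ccc2c(c1)B(O)OC2)c1ccco1` gives 20700 nM and compound 2 `Cn1cccc1C(=O)/C=C/c1ccc2c(c1)B(O)OC2` gives 93600 nM; a 15-fold lower number from compound 1 to compound 3 (1.17 log units; beyond the scatter) and a 67-fold lower number from compound 2 to compound 3 (1.83 log units; beyond the scatter), while a 4.5-fold higher number from compound 1 to compound 2 (0.66 log units; beyond the scatter). Compound 4 `O=C(/C=C/c1ccc2c(c1)B(O)OC2)c1ccc(Cl)cc1` differs from compound 3 by chloro in place of fluoro on an aromatic carbon. Within the data shown here, none of the measured steps bears directly on this exchange: all three replace the whole ring on the carbonyl carbon, and they run from modest to large. Among the measured compounds shown here, a halogen swap on the retained ring has no precedent, so in this assay a step no larger than the scatter is expected, in either direction. Compound 4 is therefore estimated at 1100 nM, with a range of 350 nM to 3500 nM, meaning a 1.3-fold lower number from compound 3 to compound 4 (0.10 log units; within the scatter) is expected.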

Compound 4, half-maximal inhibitory concentration: 3700 nM
Compound 4: middle estimate off by 3.4-fold (0.53 log units), on the low side; measured number outside the range, above it.
By their numbers in this assay, from the lowest: compound 3; then compound 4; then compound 1; then compound 2.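

In this assay, the halogen on the 4-substituted phenyl ring is not a neutral exchange: chloro in place of fluoro gives a measurable loss (a 2.6-fold higher number from compound 3 to compound 4 (0.42 log units; beyond the scatter)). The 4-chlorophenyl group still stands well ahead of furan-2-yl (a 5.6-fold lower number from compound 1 to compound 4 (0.75 log units; beyond the scatter)) and 1-methyl-1H-pyrrol-2-yl (a 25-fold lower number from compound 2 to compound 4 (1.40 log units; beyond the scatter)), so the ring exchange outweighs the halogen step. No measured evidence accounts for the halogen step.

Open: whether the trend from fluoro to chloro extends to bromo, and how a methoxy group or an amine at this aromatic carbon would compare.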